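Swapping the group on the sulfonyl sulfur of compound 2

A few compounds are considered here, and "the series" means these few. Any claim that something is new, unique, unknown or untested is made for them only; others in the source may bear on it.

- compound 1 `CC(C)S(=O)(=O)c1c(Cl)ccc(NC(=O)Nc2cccc(Cl)c2Cl)c1O`: 290 ng.h/mL
- compound 2 `CN1CC[C@H](S(=O)(=O)c2c(Cl)ccc(NC(=O)Nc3cccc(F)c3Cl)c2O)C1`: 432 ng.h/mL
- compound 3 `C[C@@H]1CN(S(=O)(=O)c2c(Cl)ccc(NC(=O)Nc3cccc(Cl)c3Cl)c2O)C[C@H](C)O1`: 519 ng.h/mL

These three numbers come from an ADME assay on the whole organism (blood, Mus musculus, strain C57BL/6) for pharmacokinetics, read by HPLC, with a stated time of 4 h, at a dose of 2 mg/kg by the intraperitoneal route; a lower number here means less compound in the circulation, a higher number more compound in the circulation at the dose given. There, compound 2 gives 432 ng.h/mL, which lies within the usual scatter of the numbers for both compound 1 and compound 3. The three compounds therefore cannot be ranked with any confidence.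

Compound 4 `CC(C)N1CCN(S(=O)(=O)c2c(Cl)ccc(NC(=O)Nc3cccc(F)c3Cl)c2O)CC1` differs from compound 2 in one place, on a sulfonyl sulfur: 4-isopropylpiperazin-1-yl in place of 1-methylpyrrolidin-3-yl on a sulfonyl sulfur. In words, 4-isopropylpiperazin-1-yl takes the place of 1-methylpyrrolidin-3-yl. Within the data shown here, no measured compound carries the entering group, so the evidence is indirect.

One measured step also exchanges a group on a sulfonyl sulfur, with 2,6-dimethylmorpholin-4-yl in place of isopropyl. It is a 1.8-fold higher number from compound 1 to compound 3 (0.25 log units; within the scatter). Those two compounds differ from compound 2 elsewhere as well, so this step is only a rough guide. Even so, it gives no reason to expect a large move in this assay, in either direction. The expected change is a 1.0-fold higher number from compound 2 to compound 4 (0.02 log units; within the scatter), so no shift beyond the scatter is anticipated. For compound 4 the estimated value is 450 ng.h/mL, with an expected range from 220 ng.h/mL to 900 ng.h/mL.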

Compound 4, area under the concentration-time curve: 52.9 ng.h/mL
For compound 4 the middle estimate is 8.5-fold (0.93 log units) above the measured one, outside the stated range (below it).
By their numbers in this assay, from the lowest: compound 4; then compounds 1, 2 and 3 (each within the scatter of the next).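

In this assay, the group on the sulfonyl sulfur proves able to change the amount of compound in the circulation: 4-isopropylpiperazin-1-yl in place of 1-methylpyrrolidin-3-yl gives an 8.2-fold lower number from compound 2 to compound 4 (0.91 log units; beyond the scatter), beyond the scatter, whereas the other exchange at this position, a 1.8-fold higher number from compound 1 to compound 3 (0.25 log units; within the scatter), stays within it. The position is therefore not indifferent to what sits there, although a single exchange alters several things at once: the entering group has 9 heavy atoms against 6, a six-membered ring with 2 hetero atoms against a five-membered ring with 1, and no defined stereocentre. Nothing available here accounts for the lower number.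

The compounds shown leave open which of these differences matters, or whether the isopropyl group alone carries the change. A 4-methylpiperazin-1-yl or a piperidin-1-yl group on the same sulfonyl sulfur, with the rest of compound 2 unchanged, would help to separate the effect of the isopropyl group from those of the ring size and the second ring nitrogen.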